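Removing a Methoxy Group: Expected Anticonvulsant Dose of Compound 4

A few compounds are considered here, and "the series" means these few. Any claim that something is new, unique, unknown or untested is made for them only; others in the source may bear on it.

Of the compounds shown here, three have been measured in a functional assay on the whole organism (strain albino) with Mus musculus as the target, in the maximal electroshock model, with a stated time of 0.5 h; a higher number here means that more compound is needed for the effect, a lower number that less compound is needed. Compound 1 `COc1ccc(Nc2nnc(Nc3nc(-c4ccc(Br)cc4)cs3)s2)cc1` gives 30 mg/kg in this assay. Compound 2 `Brc1ccc(-c2csc(Nc3nnc(Nc4ccccc4)s3)n2)cc1` is the analogue of compound 1 in which the change hydrogen in place of methoxy on an aromatic carbon has been made, and in this assay compound 2 gives 300 mg/kg; the step is a 10-fold higher number from compound 1 to compound 2 (1.00 log units; beyond the scatter). Compound 3 `COc1ccc(Nc2nnc(Nc3nc(-c4ccc([N+](=O)[O-])cc4)cs3)s2)cc1` differs from compound 1 by nitro in place of bromo on an aromatic carbon, and in this assay compound 3 gives 30 mg/kg, which is no change at the digits printed from compound 1 to compound 3 (within the scatter), so compounds 1 and 3 stand together at the lowest numbers of the three.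

Compound 4 `O=[N+]([O-])c1ccc(-c2csc(Nc3nnc(Nc4ccccc4)s3)n2)cc1` has not yet been measured. It is related to compound 3 by hydrogen in place of methoxy on an aromatic carbon, the same change that turns compound 1 into compound 2, at the same place on the ring. The two pairs differ only in their cores, and that difference is the one described by nitro in place of bromo on an aromatic carbon. Among the measured compounds shown here, since that core difference made no change at the digits printed between compound 1 and compound 3, the account rests on the single measured instance of the methoxy-to-hydrogen change. For compound 4 in this assay a step of about a 10-fold higher number from compound 3 to compound 4 (1.00 log units; beyond the scatter) is expected, matching the size seen in a 10-fold higher number from compound 1 to compound 2 (1.00 log units; beyond the scatter). For the measured compounds named here, compound 4 is therefore estimated to give 300 mg/kg in this assay, with the plausible range running from 100 mg/kg to 900 mg/kg, the width reflecting that only one prior instance of this change exists.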

Compound 4, minimum effective dose: 100 mg/kg
The estimate for compound 4 lay 3.0-fold (0.48 log units) above the measured number, and the stated range covers the measured number.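

Taking away the methoxy group raises the number on both cores in this assay, and on the nitro core the result is a 3.3-fold higher number from compound 3 to compound 4 (0.52 log units; beyond the scatter), so the direction carries over from the bromo series but the size does not: the same change on two cores in this assay, a 10-fold higher number (1.00 log units; beyond the scatter) from compound 1 to compound 2 and a 3.3-fold higher number (0.52 log units; beyond the scatter) from compound 3 to compound 4, 3.0-fold (0.48 log units) apart, beyond the scatter of two such steps The same holds when the pairs are read the other way, since nitro in place of bromo, silent while the methoxy group is present, gives a 3.0-fold lower number from compound 2 to compound 4 (0.48 log units; beyond the scatter) once it is gone, and the two readings do not agree: the same change on two cores in this assay, no change at the digits printed (within the scatter) from compound 1 to compound 3 and a 3.0-fold lower number (0.48 log units; beyond the scatter) from compound 2 to compound 4, 3.0-fold (0.48 log units) apart, beyond the scatter of two such steps Together these four compounds show that the two changes do not add independently here, but with one pair on each core they show neither why the size shifts nor whether the direction would hold on a third core.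

The compounds shown leave open whether the gain lies in the methoxy group itself or would also come with another group in its place, such as an ethoxy group, a hydroxyl, a chlorine or a dimethylamino group. They also leave open how an amine or a carboxylic acid in place of the bromo or nitro group would behave, with or without the methoxy group present.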